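The source may report more compounds than this note shows. Statements on the series, on what has been measured and on what is new or still open speak of the compounds shown alone.

Working notes on the phthalimide-bearing triazole series. In a functional assay on MKN-45 cells (Homo sapiens) for cytotoxicity, read by MTT assay, with a stated time of 48 h (a higher number here means a weaker inhibitor, a lower number a stronger inhibitor), compound 1 `CCOC(=O)CSc1nnc(CC)n1N1C(=O)c2ccccc2C1=O` returns only a limit, > 200000 nM, not a number. Compound 2 `CCCc1nnc(SCC(=O)c2ccccc2)n1N1C(=O)c2ccccc2C1=O` likewise gives a limit in this assay, > 200000 nM. Within the data shown here, compound 3 `C=CCSc1nnc(-c2cc(OC)c(OC)c(OC)c2)n1N1C(=O)c2ccccc2C1=O` also sits at a limit in this assay, > 200000 nM, so its standing among the three measured compounds cannot be ranked: all three values are the same limit, and the limit of > 200000 nM in this assay, at which 3 of the 3 values shown sit, is the only evidence available on the series. Among the measured compounds shown here, nothing among the measured compounds shows a step beyond the scatter.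

Compound 4 `COc1cc(-c2nnc(SCC(=O)c3ccc(F)cc3)n2N2C(=O)c3ccccc3C2=O)cc(OC)c1OC` is the next member to be measured in this assay. It differs from compound 3 by (4-fluorophenyl)carbonyl in place of vinyl on a saturated chain carbon bound to a sulfur. Compound 2 already carries a phenylcarbonyl-methylsulfanyl arm of the same kind and returns a limit in this assay, > 200000 nM, which gives no sign that such an arm brings the value down into the measurable range.

The step from compound 3 to compound 4 is therefore expected to be none beyond the scatter, a step that the limit leaves unreadable from compound 3 to compound 4. Compound 4 is expected to return a value at or near the limit in this assay, 250000 nM, within 60000 nM to 1000000 nM.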

Compound 4, half-maximal inhibitory concentration: 126000 nM
Estimate against measurement, compound 4: 2.0-fold (0.30 log units) above, and the stated range covers the measured number.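

In this assay compound 4 is the only compound shown that gives a number rather than a limit, so the group on a saturated chain carbon bound to a sulfur can now be linked to a measurable value. Placing (4-fluorophenyl)carbonyl there in place of vinyl gives an at least 1.5-fold lower number from compound 3 to compound 4 (0.20 log units; that floor lies within the scatter). That figure is a floor and not a size, as one end of the step is a limit, so the change is not shown to exceed the scatter, and the remaining values add no second number to set beside it: the limit of > 200000 nM in this assay, at which 3 of the 4 values shown sit.

The compounds shown do not separate the fluorine, the carbonyl and the aromatic ring of the entering group, so it remains open which of these, if any, goes with the number for compound 4. From the compounds shown here alone, it also remains open whether an amine, a carboxylic acid or a longer chain at this place would give a number at all, or one clearly lower than that of compound 4.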